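This account rests on a few compounds, and the source may have more. Where it says the series, first, only, none or still open, it means among the compounds named here.

Among the measured compounds shown here, compound 1 `CC(=O)c1cccc(Nc2ccnc(SCC(=O)c3ccc(-c4ccccc4)cc3)n2)c1` is one of two compounds measured in a functional assay on HCT-116 cells (Homo sapiens) for inhibition, read by sulforhodamine B assay, with a stated time of 48 h, tested at 10 uM (on this read-out higher numbers stand for more inhibition of growth at the one concentration tested and lower numbers for less inhibition of growth), where compound 1 gives 14%. That is the lower of the two numbers: compound 2 `CC(=O)c1cccc(Nc2ccnc(SCC(=O)c3ccc(C(F)(F)F)cc3)n2)c1` gives 28% in this assay, and the change of trifluoromethyl in place of phenyl on an aromatic carbon produces a number 14 percentage points higher from compound 1 to compound 2 (beyond the scatter).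

Compound 3 `CC(=O)c1ccc(Nc2ccnc(SCC(=O)c3ccc(-c4ccccc4)cc3)n2)cc1` has not yet been measured in this assay. It is built from the same atoms as compound 1, joined differently: 4-acetylphenyl in place of 3-acetylphenyl on a nitrogen on an aromatic ring. For the measured compounds named here, the only measured step, a number 14 percentage points higher from compound 1 to compound 2 (beyond the scatter), alters a different part of the shared core, the group beyond the carbonyl on the sulfur side, and leaves the acetylphenyl untouched, so no measured step speaks directly to this change. With nothing to point either way, the expectation for compound 3 is a number close to that of compound 1, and the step of a number 4 percentage points higher from compound 1 to compound 3 (within the scatter) is estimated to stay within the usual scatter. Compound 3 is therefore estimated to give 18% in this assay, with a range from 2% to 38%.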

Compound 3, percent growth inhibition at one concentration: 42%
Compound 3: the middle estimate sits 24 percentage points below what was measured; measured number above the stated range.
By their numbers in this assay, from the lowest: compound 1; then compound 2; then compound 3.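

Swapping 3-acetylphenyl for 4-acetylphenyl on a nitrogen on an aromatic ring gives a number 28 percentage points higher from compound 1 to compound 3 (beyond the scatter) in this assay, even though the group that leaves and the group that enters have the same atoms and the same counts of rings, donors and acceptors. So the read-out depends on how the acetylphenyl group is joined to the rest of the molecule, not only on which atoms are present, and this part of the structure matters as well as the group beyond the carbonyl on the sulfur side, where the earlier change gave a number 14 percentage points higher from compound 1 to compound 2 (beyond the scatter). Nothing available here explains why this rearrangement of the same atoms changes the number.

The compounds shown leave open whether the same swap would give a step of similar size in compound 2, which carries trifluoromethyl in place of phenyl. They also leave open what would happen if a different group, such as a carboxylic acid, an amine or a nitrile, replaced the acetyl group on the 4-acetylphenyl ring.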